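Closing the phenylethyl into a cyclopropyl on the sulfonyl

The source may hold more compounds than are shown below. What is called first, only, known or untested is meant among the compounds shown, and "the series" means these compounds.

Compound 1 `CC(c1ccccc1)S(=O)(=O)NC(=O)C1CCN(c2nc3c(cc2C#N)C(=O)OC3)CC1`: 4160 nM
Compound 2 `CC(c1ccccc1)S(=O)(=O)NC(=O)C1(F)CCN(c2nc3c(cc2C#N)C(=O)OC3)CC1`: 9950 nM

In a functional assay (Platelet, plasma) for inhibition, with Homo sapiens as the target (on this read-out higher numbers stand for weaker inhibition and lower numbers for stronger inhibition), compound 1 gives the lowest of the two numbers; its nearest neighbour is compound 2, reached by a 2.4-fold higher number from compound 1 to compound 2 (0.38 log units; beyond the scatter). Compound 3 `N#Cc1cc2c(nc1N1CCC(C(=O)NS(=O)(=O)C3(c4ccccc4)CC3)CC1)COC2=O` differs from compound 1 by 1-phenylcyclopropyl in place of 1-phenylethyl on a sulfonyl sulfur. Going by the values given here, the one measured step concerns a different part of the molecule, so no step bears directly on this change, and there is no ground for expecting more than a small shift in this assay. Compound 3 is therefore expected to give about 4500 nM (range 1500 nM to 13000 nM), a step of a 1.1-fold higher number from compound 1 to compound 3 (0.03 log units; within the scatter).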

Compound 3, half-maximal inhibitory concentration: 4100 nM
The estimate for compound 3 lay 1.1-fold (0.04 log units) above the measured number, within the range that was stated.
By their numbers in this assay, from the lowest: compounds 3 and 1 (each within the scatter of the next); then compound 2.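

In this assay, 1-phenylcyclopropyl in place of 1-phenylethyl on a sulfonyl sulfur leaves the number unchanged within the scatter (a 1.0-fold lower number from compound 1 to compound 3 (0.01 log units; within the scatter)). Going by these compounds alone, the earlier step concerned only a saturated ring carbon, so this is the first reading at this position, and it shows that the position accepts the three-membered ring. Nothing measured here explains why the two groups read alike.

Still open, from the compounds shown here alone, is how methyl or a simple amine would read on the sulfonyl sulfur. Going by these compounds, it is also open whether fluoro on the saturated ring carbon of compound 3 would repeat the step seen earlier (a 2.4-fold higher number from compound 1 to compound 2 (0.38 log units; beyond the scatter)).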